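The compounds below may be only part of what the source reports. "The series", "measured", "known", "first", "only" and "open" are said of these compounds alone.

Compound 1 `C/C(=C\CC/C(C)=C/CC[C@@H]1[C@@]2(C)CCC(=O)C(C)(C)[C@H]2CC[C@@]1(C)O)CC/C=C(\C)C(=O)OCc1cn(-c2ccccc2[N+](=O)[O-])nn1` was tested in a functional assay on A549 cells (Homo sapiens) for antiproliferative activity, read by MTT assay, with a stated time of 48 h; a lower number here means a stronger inhibitor, a higher number a weaker inhibitor. In this assay compound 1 gives only a limit, > 150000 nM, so no number is known for it (the limit of > 150000 nM in this assay, at which 1 of the 2 values shown sits). Compound 2 `C/C(=C\CC/C(C)=C/CC[C@@H]1[C@@]2(C)CCC(=O)C(C)(C)[C@H]2CC[C@@]1(C)O)CC/C=C(\C)C(=O)OCc1cn(C[C@@H]2O[C@H](n3ccc(=O)[nH]c3=O)C[C@H]2O)nn1` gives 28100 nM in this assay. Compound 3 `C/C(=C\CC/C(C)=C/CC[C@@H]1[C@@]2(C)CCC(=O)C(C)(C)[C@H]2CC[C@@]1(C)O)CC/C=C(\C)C(=O)OCc1cn(-c2cccc(Br)c2)nn1` has not yet been measured; it differs from compound 1 by 3-bromophenyl in place of 2-nitrophenyl on an aromatic nitrogen. Because compound 1 sits at the limit (the limit of > 150000 nM in this assay, at which 1 of the 2 values shown sits), no step size can be read from the data, and the step of an at least 1.5-fold lower number from compound 1 to compound 3 (0.17 log units; that floor lies within the scatter) that the estimate implies is therefore expected to be uncertain and weakly in the stronger direction. Compound 3 is expected to give about 100000 nM, ranging from 30000 nM to 300000 nM.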

Compound 3, half-maximal inhibitory concentration: > 150000 nM
Compound 3 gave a limit, no number; the forecaster's own chance of this, stated with the estimate: 45%; middle value at least 1.5-fold (0.17 log units) away from the limit.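

No step can be read between compound 1 and compound 3, since both give only a limit in this assay: the limit of > 150000 nM in this assay, at which 2 of the 3 values shown sit.

As far as these compounds go, whether 2-nitrophenyl or 3-bromophenyl on the aromatic nitrogen gives the stronger inhibitor remains open.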